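From an Acetylpropyl Chain to a Methylsulfonylphenyl Ring

The compounds below may be only part of what the source reports. "The series", "measured", "known", "first", "only" and "open" are said of these compounds alone.

Of the compounds shown here, three built on one shared core have been measured in an assay on HEK293 cells for inhibition of N-acylethanolamine-hydrolyzing acid amidase (Homo sapiens), read by fluorescence, with stated times of 10 min and 50 min; a higher number here means a weaker inhibitor, a lower number a stronger inhibitor. Compound 1, `COC(=O)N1C[C@H](NC(=O)OCCCCC2CCCCC2)C1=O`, gives 7180 nM in this assay. Compound 2, `CON1C[C@@H](NC(=O)OCCCCC2CCCCC2)C1=O`, gives 56 nM. Compound 3, `CC(=O)CCCON1C(=O)[C@@H](NC(=O)OCCCCC2CCCCC2)[C@@H]1C`, gives 75 nM.

Among these three numbers compound 3 stands second highest. Its nearest neighbour is compound 2, whose number differs from it by an amount that lies within the usual scatter of repeated measurements, so the two cannot be told apart on this evidence. The furthest is compound 1, whose number lies far higher than that of compound 3, well beyond the scatter.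

Compound 4, `C[C@H]1[C@H](NC(=O)OCCCCC2CCCCC2)C(=O)N1Oc1ccccc1S(C)(=O)=O`, has not yet been measured. It differs from compound 3 in one place: 2-(methylsulfonyl)phenyl in place of 3-acetylpropyl on an oxygen. Among the compounds with values here, no pair of measured compounds shows a change of this kind, so there is no measured step to lean on. The step from compound 3 to compound 4 in this assay is expected to be a 1.6-fold higher number from compound 3 to compound 4 (0.20 log units; within the scatter), a small shift that may well stay within the scatter. On that basis compound 4 is estimated to give 120 nM in this assay, with a range from 30 nM to 500 nM.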

Compound 4, half-maximal inhibitory concentration: 6 nM
For compound 4 the middle estimate is 20-fold (1.30 log units) above the measured one; the whole stated range lies above it.
By their numbers in this assay, from the lowest: compound 4; then compounds 2 and 3 (each within the scatter of the next); then compound 1.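

Within the data shown here, exchanging 3-acetylpropyl for 2-(methylsulfonyl)phenyl on the oxygen bound to the amide-type nitrogen in a ring gives, in this assay, a 13-fold lower number from compound 3 to compound 4 (1.10 log units; beyond the scatter), a large step and the first measured change at this position. It shows that this oxygen can carry a six-membered aromatic ring of carbon only, with more heavy atoms than the open chain it replaces, and that the group placed here can move the number well beyond the scatter without any loss. No evidence is available that bears on the reason for this step.

The phenyl ring and the methylsulfonyl group entered together, so their shares in the step remain unresolved, and an unsubstituted phenyl or a phenyl carrying a nitrile or a carboxylic acid in place of the methylsulfonyl group would be needed to separate them. The compounds shown also leave open whether 2-(methylsulfonyl)phenyl would produce a step of similar size on the core of compound 2, or how a benzyl group or an aminoalkyl chain on the same oxygen would compare.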